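The source may hold more compounds than are shown below. What is called first, only, known or untested is meant among the compounds shown, and "the series" means these compounds.

In a functional assay on PC-3 cells (Homo sapiens) for cytotoxicity, read by WST assay, with a stated time of 3 days (a lower number here means a stronger inhibitor, a higher number a weaker inhibitor), compound 1 `CCCn1ccnc1/C=C/C(=O)/C=C/c1coc2ccccc2c1=O` gives 2400 nM and compound 2 `CCCCCn1ccnc1/C=C/C(=O)/C=C/c1coc2ccccc2c1=O` gives 2100 nM, so compound 2 stands level with compound 1 within the usual scatter. Compound 3 `CCC(CC)n1ccnc1/C=C/C(=O)/C=C/c1coc2ccccc2c1=O` has the same atoms as compound 2, joined differently: pentan-3-yl in place of pentyl on an aromatic nitrogen. Going by the values given here, the one measured step that bears on this is a 1.1-fold lower number from compound 1 to compound 2 (0.06 log units; within the scatter), and it changes only the chain length. Among the compounds with values here, no measured compound carries pentan-3-yl, so this evidence is limited, and no shift beyond the scatter is expected in this assay. The estimated change is a 1.0-fold higher number from compound 2 to compound 3 (0.02 log units; within the scatter). Compound 3 is expected at 2200 nM, within a range of 1000 nM to 4800 nM.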

Compound 3, half-maximal inhibitory concentration: 2900 nM
Beside the measured number, compound 3's estimate is 1.3-fold (0.12 log units) below it; measured number inside the range.
By their numbers in this assay, from the lowest: compounds 2, 1 and 3 (each within the scatter of the next).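

In this assay, pentan-3-yl in place of pentyl on an aromatic nitrogen gives a 1.4-fold higher number from compound 2 to compound 3 (0.14 log units; within the scatter), so at this position a branched chain and a straight one of the same size cannot be told apart. The wider comparison, a 1.2-fold higher number from compound 1 to compound 3 (0.08 log units; within the scatter), is also within the scatter, so all three chains shown read alike here. Nothing available explains why these numbers stay so close. Still open, from the compounds shown here alone, is whether a different group on this nitrogen, such as a carboxylic acid, an amine or a much longer chain, would move the number beyond the scatter.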